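The compounds below may be only part of what the source reports. "The series", "measured", "known", "first", "only" and "open" are said of these compounds alone.

Compound 1, with the structure `C=C1C[C@]23C[C@@]1(O)CC[C@H]2c1ccc(O)c(C)c1[C@@H]3Cn1cc(-c2ccc(OC)cc2)nn1`, was tested in a functional assay on SMMC-7721 cells (Homo sapiens) for cytotoxicity, read by MTT assay, with a stated time of 4 days; on this read-out higher numbers stand for weaker inhibition and lower numbers for stronger inhibition. In this assay compound 1 gives only a limit, > 20000 nM, and no number. Two close relatives were tested alongside it. Compound 2, with the structure `C=C1C[C@]23C[C@@]1(O)CC[C@@H]2c1cccc(C)c1[C@@H]3Cn1cc(-c2ccc(OC)cc2)nn1`, gives in this assay the limit > 20000 nM, again a limit rather than a number. Compound 3, with the structure `Cc1c(O)ccc2c1[C@H](Cn1cc(-c3ccccn3)nn1)[C@@]13CC(=O)[C@@](C)(CC[C@@H]21)C3`, gives in this assay the limit > 20000 nM, likewise a limit. So compound 1 stands where every measured compound stands: at the limit of the assay, as summarised by the limit of > 20000 nM in this assay, at which 3 of the 3 values shown sit.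

The next compound, compound 4, has the structure `C=C1C[C@]23C[C@@]1(O)CC[C@H]2c1ccc(O)c(C)c1[C@@H]3Cn1cc(-c2ccccc2)nn1`. It differs from compound 1 in one place, described as hydrogen in place of methoxy on an aromatic carbon: the methoxy leaves and a hydrogen enters, so that the 4-methoxyphenyl becomes a plain phenyl. Going by the values given here, no step between two measured compounds is available to show what such a change does here, and all three measured values are limits, so there is no measured step in this assay to lean on.

The expectation is therefore the simplest one: a step that the limit leaves unreadable from compound 1 to compound 4 that amounts to nothing beyond the scatter, with compound 4 most likely ending up at the limit as well. The estimate for compound 4 in this assay is 30000 nM, in a range from 10000 nM to 100000 nM.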

Compound 4, half-maximal inhibitory concentration: > 20000 nM
Compound 4: a limit, no number; the forecaster's own chance of this, stated with the estimate: 80%; the middle value is on the limit's open side.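

In this assay compound 4 gives > 20000 nM, a limit and not a number. Compound 1 also gives only a limit, so the step between compound 1 and compound 4 cannot be read. The compounds shown leave open what swapping methoxy for hydrogen does to activity, and none of them yields an actual number: the limit of > 20000 nM in this assay, at which 4 of the 4 values shown sit.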